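This account rests on a few compounds, and the source may have more. Where it says the series, first, only, none or still open, it means among the compounds named here.

In an ADME assay on GES1 cells (Homo sapiens) for cytotoxicity, read by MTT assay, with a stated time of 24 h (on this read-out higher numbers stand for lower toxicity in this test and lower numbers for higher toxicity in this test), compound 1 `Cc1ccccc1-n1cc(-c2cccc(NS(=O)(=O)c3c[nH]c(=O)[nH]c3=O)c2)nn1` gives 21500 nM. Compound 2 `O=c1[nH]cc(S(=O)(=O)Nc2cccc(-c3cn(-c4ccc(F)cc4)nn3)c2)c(=O)[nH]1` carries a different group on the same core; in this assay compound 2 is reported as "not toxic" (no number reported), so no single number fixes where it stands. Compound 3 `O=c1[nH]cc(S(=O)(=O)Nc2cccc(-c3cn(-c4ccccc4Cl)nn3)c2)c(=O)[nH]1` differs from compound 2 in one place: 2-chlorophenyl in place of 4-fluorophenyl on an aromatic nitrogen. Among the measured compounds shown here, no measured pair shows what such a swap does in this assay, so no shift beyond the usual scatter is assumed in either direction. Compound 3 is expected to give about 40000 nM in this assay, within 15000 nM to 110000 nM, with a fair chance that only a limit is reported.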

Compound 3, half-maximal cytotoxic concentration: 14000 nM
For compound 3 the middle estimate is 2.9-fold (0.46 log units) above the measured one; measured number outside the range, below it.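

Chloro in place of methyl on an aromatic carbon gives a 1.5-fold lower number from compound 1 to compound 3 (0.19 log units; within the scatter) in this assay and so the two groups cannot be told apart on this aromatic ring in this test. The swap from 4-fluorophenyl to 2-chlorophenyl still cannot be read as a step: compound 2 carries only the words "not toxic" and no number. Nothing given here explains the result.
Going by these compounds, it remains open how a plain phenyl ring would read in this position. The same holds for a phenyl ring bearing an amine or a carboxylic acid.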